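A few compounds are considered here, and "the series" means these few. Any claim that something is new, unique, unknown or untested is made for them only; others in the source may bear on it.

Measured so far:
compound 1 `Cc1c(OCC2=NCCN2)ccc(Cl)c1NS(C)(=O)=O`: 25 nM
compound 2 `Clc1ccc2c(c1-c1ccn[nH]1)CCC2c1ncc[nH]1`: 322 nM
compound 3 `Cn1cc(-c2cccc3c2CCC3c2ncc[nH]2)cn1`: > 2900 nM

In a functional assay on CHO cells for agonist activity at Alpha-1A adrenergic receptor (Homo sapiens), read by FLIPR and calcium flux (on this read-out lower numbers stand for an effect already at smaller amounts and higher numbers for an effect only at larger amounts of compound), compound 1 gives 25 nM and compound 2 gives 322 nM. For compound 3 the read-out is only a limit, > 2900 nM, which is the limit of > 2900 nM in this assay, at which 1 of the 3 values shown sits. Among the measured compounds shown here, none of these three compounds differs from another in a single place, so no measured step is available in this assay.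

Compound 4 `Cn1ccc(-c2cccc3c2CCC3c2ncc[nH]2)n1` differs from compound 3 in one place: 1-methyl-1H-pyrazol-3-yl in place of 1-methyl-1H-pyrazol-4-yl on an aromatic carbon. Compound 4 is expected to stay close to compound 3 in this assay, the step that the limit leaves unreadable from compound 3 to compound 4 estimated as small and of no settled direction, likely within the scatter. For compound 4 the estimate is 3500 nM, with a range from 800 nM to 15000 nM.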

Compound 4, half-maximal effective concentration: > 1300 nM
Compound 4 was reported as a limit (the forecaster's own chance of this, stated with the estimate: 60%); the middle value lies beyond the limit too.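

Among the compounds shown here, compound 3 and compound 4 are both reported only as limits, and no step between them can be read. The compounds shown leave open whether 1-methyl-1H-pyrazol-3-yl and 1-methyl-1H-pyrazol-4-yl differ at all in effect.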